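The source may hold more compounds than are shown below. What is called first, only, known or untested is meant among the compounds shown, and "the series" means these compounds.

Three compounds that all carry a nitro group on a shared core have been measured in a physicochemical assay for lipophilicity, measured as octanol-water partition; a higher number here means a more lipophilic compound, a lower number a more polar compound. In this assay compound 1 `NC(=O)c1nc2ccccn2c1[N+](=O)[O-]` gives -0.515. In this assay compound 2 `Cc1cccc2nc(C(N)=O)c([N+](=O)[O-])n12` gives 0.67. The change from compound 2 to compound 1 is hydrogen in place of methyl on an aromatic carbon and it gave a number 1.19 log units lower from compound 2 to compound 1 (beyond the scatter).

Compound 3 `Cc1cccc2nc(NC3CCCCC3)c([N+](=O)[O-])n12` has a different core; how the two cores differ is not broken down here. In this assay compound 3 gives 1.56, the highest of the three numbers.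

Compound 4 `O=[N+]([O-])c1c(NC2CCCCC2)nc2ccccn12` has not been measured yet. It differs from compound 3 by hydrogen in place of methyl on an aromatic carbon, the same change that was made from compound 2 to compound 1, at the same place on the ring. Because a number 1.19 log units lower from compound 2 to compound 1 (beyond the scatter) the change is expected to lower the number again, and the step is estimated as a number 1.11 log units lower from compound 3 to compound 4 (beyond the scatter). On that basis compound 4 is expected to come out near 0.45 in this assay, most likely between -0.1 and 1.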

Compound 4, partition coefficient: 1.54
Beside the measured number, compound 4's estimate is 1.09 log units below it, and the stated range ends below it.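

In this assay, putting hydrogen in place of methyl on an aromatic carbon gave a number 1.19 log units lower from compound 2 to compound 1 (beyond the scatter) on the first core, while the same change at the same place on the ring gave a number 0.02 log units lower from compound 3 to compound 4 (within the scatter) on the second core. This shows that the size of the step seen on one core did not carry over to the other, so in this series a step read from one pair cannot simply be added to a compound on a different core. It does not show what sets the two cores apart in this respect, or that the change does nothing in general on the core of compound 3, and nothing given here explains the contrast.

Going by these compounds alone, with only one pair on each core, it stays open how the same change would read on a third core. From the compounds shown here alone, it also stays open how an ethyl group or a chlorine atom in place of the methyl would read on either core.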